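The source may report more compounds than this note shows. Statements on the series, on what has been measured and on what is new or still open speak of the compounds shown alone.

Compound 1 `NC(=S)N/N=C/c1ccc2ccccc2n1`: 32700 nM
Compound 2 `COc1ccc(C)cc1NC(=S)N/N=C/c1ccc2ccccc2n1`: > 100000 nM, a limit of the assay, not a number
Compound 3 `CC(C)c1cccc(C(C)C)c1NC(=S)N/N=C/c1ccc2ccccc2n1`: 23500 nM

In a functional assay on SGC-7901 cells (Homo sapiens) for antiproliferative activity, read by sulforhodamine B assay, with a stated time of 72 h (on this read-out lower numbers stand for stronger inhibition and higher numbers for weaker inhibition), compound 1 gives 32700 nM, which is the highest of the two numbers present. Compound 3 gives 23500 nM, a value within the scatter of compound 1, so the two stand level and neither can be ranked against the other. Compound 2 reaches only > 100000 nM, which is a limit of the assay and not a number. That value is the limit of > 100000 nM in this assay, at which 1 of the 3 values shown sits.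

Compound 4 `S=C(N/N=C/c1ccc2ccccc2n1)Nc1ccccc1Br` differs from compound 1 in one place: 2-bromophenyl in place of hydrogen on an amide-type nitrogen. For the measured compounds named here, no measured pair differs in exactly one place, so no step of known size is available. The two other substitutions on the same nitrogen, in compound 2 and compound 3, give one limit and one number level with compound 1. On that basis the step of a 1.1-fold lower number from compound 1 to compound 4 (0.04 log units; within the scatter) in this assay is expected to be none beyond the scatter, with some risk of a limit. Compound 4 is estimated at 30000 nM, between 8000 nM and 100000 nM.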

Compound 4, half-maximal inhibitory concentration: > 100000 nM
Compound 4: only a limit was reported (the forecaster's own chance of this, stated with the estimate: 25%); middle value at least 3.3-fold (0.52 log units) from the limit.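

In this assay, the series now has its first readable single-place step, an at least 3.0-fold higher number from compound 1 to compound 4 (0.48 log units; beyond the scatter), and it shows that putting 2-bromophenyl in place of hydrogen on this amide-type nitrogen can cost activity beyond the scatter. An aryl group at this nitrogen does not always bring that loss, and compound 3 goes against any such pattern with 23500 nM. Compound 4 gives > 100000 nM, a limit of the assay and not a number, so the step has a floor but no known full size, and the series now holds a second compound at that limit: the limit of > 100000 nM in this assay, at which 2 of the 4 values shown sit.

From the compounds shown here alone, it remains open whether the loss follows the bromine or the phenyl ring itself, which unsubstituted phenyl would help separate. Also open, going by these compounds, is how a small methyl, a longer alkyl chain or a chain ending in an amine would behave on this nitrogen.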